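From Propoxycarbonyl to Bromomethyl on a Shared Core

This account rests on a few compounds, and the source may have more. Where it says the series, first, only, none or still open, it means among the compounds named here.

In a functional assay on SK-BR-3 cells (Homo sapiens) for cytotoxicity, read by MTT assay, with a stated time of 72 h (a higher number here means that more compound is needed for the effect, a lower number that less compound is needed), compound 2 (`CCCOC(=O)c1c(C)coc1-c1ccc2c(CC)cccc2c1OC`) gives > 10 ug/mL as its result, and this is a limit of the assay, not a number. Two relatives without the propoxycarbonyl group do give numbers: compound 1 (`CCc1cccc2c(O)c(-c3occ(C)c3C(=O)O)ccc12`) reads 1 ug/mL and compound 3 (`CCOc1c(-c2occ(C)c2CO)ccc2c(CC)cccc12`) reads 8.8 ug/mL in the same test. Compound 4 (`CCc1cccc2c(OC)c(-c3occ(C)c3CBr)ccc12`) keeps the rest of compound 2 but has bromomethyl in place of propoxycarbonyl on an aromatic carbon. Going by the values given here, no measured pair tests this swap directly. The expected shift is an at least 2.0-fold lower number from compound 2 to compound 4 (0.30 log units; that floor lies within the scatter) and points towards less compound being needed, judging only from those two relatives. Compound 4 is estimated at 5 ug/mL with a range of 1.2 ug/mL to 18 ug/mL expected.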

Compound 4, concentration for half-maximal effect: > 10 ug/mL
Compound 4 ended at the assay's limit; the forecaster's own chance of this, stated with the estimate: 25%; middle value at least 2.0-fold (0.30 log units) away from the limit.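

No step can be read between compound 2 and compound 4 because both end at a limit of the assay, not at a number: the limit of > 10 ug/mL in this assay, at which 2 of the 4 values shown sit. The compounds shown leave open whether bromomethyl or propoxycarbonyl gives the lower number on this shared core.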